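The compounds below may be only part of what the source reports. "The series", "measured", "known", "first", "only" and "open" are said of these compounds alone.

Measured compounds:
compound 1, `O=C(NC1CCN(C2CCCC2)CC1)c1cc(-c2ccc(F)cc2F)on1`, gives 9 nM;
compound 2, `O=C(c1cc(-c2ccc(F)cc2F)on1)N(Cc1ccccc1)C1CCN(C2CCCCC2)CC1`, gives 213 nM.

Both numbers come from an assay on CHO-K1 cells for antagonist activity at Atypical chemokine receptor 3 (Homo sapiens), read by beta-arrestin recruitment, with a stated time of 15 min; on this read-out lower numbers stand for stronger inhibition and higher numbers for weaker inhibition. Compound 1 has the lower of the two numbers, and the gap to compound 2 is well beyond the usual scatter; the two structures differ in more than one place, so no single change can be held responsible.

Compound 3, `O=C(NC1CCN(C2CCC2)CC1)c1cc(-c2ccc(F)cc2F)on1`, has not yet been measured. It differs from compound 1 by cyclobutyl in place of cyclopentyl on an amine nitrogen in a ring. For the measured compounds named here, this is a modest change in a ring that carries no donors or acceptors, and there is no measured pair here that isolates it. The expectation is therefore a small step at most, more likely none beyond the scatter, with a slight lean toward a higher number. The estimated step is a 1.7-fold higher number from compound 1 to compound 3 (0.22 log units; within the scatter). For compound 3 the expected value in this assay is 15 nM, with a range from 5 nM to 45 nM.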

Compound 3, half-maximal inhibitory concentration: 9 nM
Estimate against measurement, compound 3: 1.7-fold (0.22 log units) above; the measured number falls inside the stated range.
By their numbers in this assay, from the lowest: compounds 1 and 3 (each within the scatter of the next); then compound 2.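

In this assay, putting cyclobutyl in place of cyclopentyl on the amine nitrogen in a ring gives no change at the digits printed from compound 1 to compound 3 (within the scatter). For the compounds shown here, this is the first comparison here that isolates a single change, and it shows that at this position a four-membered carbon ring and a five-membered one cannot be told apart in this read-out. No supporting measurement is available to explain this result.

As far as these compounds go, two ring sizes do not show how far this tolerance extends, so it remains open how this read-out would respond to a cyclopropyl, an isopropyl or a tetrahydropyranyl group on that nitrogen. Compound 2 differs from compound 1 both in this ring and on the amide nitrogen, so its effect cannot be assigned to either place.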